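The compounds below may be only part of what the source reports. "The series", "measured", "known", "first", "only" and "open" are said of these compounds alone.

In an ADME assay on the whole organism (plasma, strain 129/SvEvBrd x C57BL/6) for pharmacokinetics, with Mus musculus as the target, at a dose of 10 mg/kg by the oral route (a higher number here means more compound in the circulation at the dose given, a lower number less compound in the circulation), compound 1 (`CN(C)C(=O)c1nc([C@@H](O)[C@H](O)[C@H](O)CO)c[nH]1`) gives 1740 ng.h/mL, compound 2 (`CC(F)(F)c1nc([C@@H](O)[C@H](O)[C@H](O)CO)c[nH]1`) gives 1190 ng.h/mL and compound 3 (`OC[C@@H](O)[C@@H](O)[C@H](O)c1c[nH]c(-c2cscn2)n1`) gives 1570 ng.h/mL, so compound 3 stands within the scatter of both others. Compound 4 (`OC[C@@H](O)[C@@H](O)[C@H](O)c1c[nH]c(-c2cocn2)n1`) differs from compound 3 at one place: 1,3-oxazol-4-yl in place of 1,3-thiazol-4-yl on an aromatic carbon. For the measured compounds named here, no measured step makes this exact exchange. Going by the values given here, the steps that bear on it change the group on that same aromatic carbon: a 1.1-fold lower number from compound 1 to compound 3 (0.04 log units; within the scatter), a 1.3-fold higher number from compound 2 to compound 3 (0.12 log units; within the scatter) and a 1.5-fold lower number from compound 1 to compound 2 (0.17 log units; within the scatter), all within the scatter. No step beyond the scatter is therefore expected in this assay. The estimate means a 1.1-fold lower number from compound 3 to compound 4 (0.05 log units; within the scatter), an expected step within the scatter. Compound 4 is expected at about 1400 ng.h/mL, with an estimated range of 650 ng.h/mL to 3000 ng.h/mL.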

Compound 4, area under the concentration-time curve: 868 ng.h/mL
Beside the measured number, compound 4's estimate is 1.6-fold (0.21 log units) above it; low and high end bracket the measured number.
By their numbers in this assay, from the lowest: compounds 4, 2, 3 and 1 (each within the scatter of the next).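

In this assay, a 1.8-fold lower number from compound 3 to compound 4 (0.26 log units; within the scatter) and a 1.4-fold lower number from compound 2 to compound 4 (0.14 log units; within the scatter) and a 2.0-fold lower number from compound 1 to compound 4 (0.30 log units; within the scatter) all remain within the scatter, so a fourth group on this aromatic carbon, between two ring nitrogen atoms, still gives no step beyond it. The exchange of 1,3-thiazol-4-yl for 1,3-oxazol-4-yl, new here, thus leaves the number within the scatter of compound 3, and the step from the dimethylcarbamoyl compound is the widest yet at this position. Nothing shown offers an explanation for these differences. As far as these compounds go, whether an amine, a carboxylic acid or a longer chain at this position would give a step beyond the scatter stays open.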